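Ethyl for methyl on the compound 2 scaffold

This account rests on a few compounds, and the source may have more. Where it says the series, first, only, none or still open, it means among the compounds named here.

compound 1 `CCCN(Cc1ccc(OCCN2C(=O)CCC2=O)c(C)c1)[C@@H](CC(=O)O)c1ccc(Cl)cc1` - 97%
compound 2 `Cc1cc(CN(CC2CCCC2)[C@@H](CC(=O)O)c2ccc(Cl)cc2)ccc1OCCN1C(=O)CCC1=O` - 78%
compound 3 `CCc1cc(CN(CC2CCCC2)[C@@H](CC(=O)O)c2ccc(Cl)cc2)ccc1OCCN1C(=O)CCC1=O` - not yet measured

In an ADME assay on liver (Homo sapiens) for metabolic stability, read by LC-MS, using microsomes and NADPH (a higher number here means that more of the compound is left, a lower number that less of the compound is left), compound 2 is the lower of the two measured, at 78%. Compound 3 differs from it by methyl in place of hydrogen on a saturated chain carbon bound to an aromatic carbon. For the measured compounds named here, the only measured step, a number 19 percentage points lower from compound 1 to compound 2 (beyond the scatter), changes a different group and was modest, so it serves only as a rough guide to size. Expected in this assay is a number 6 percentage points lower from compound 2 to compound 3 (within the scatter), a small fall not clearly beyond the scatter. For compound 3 the estimated value is 72%, with an expected range of 57% to 87%.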

Compound 3, percent of the compound remaining: 48%
Compound 3: the middle estimate sits 24 percentage points above what was measured, and the stated range ends above it.
By their numbers in this assay, from the lowest: compound 3; then compound 2; then compound 1.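

In this assay the methyl to ethyl change, on a saturated chain carbon bound to an aromatic carbon, gives a number 30 percentage points lower from compound 2 to compound 3 (beyond the scatter). This position therefore responds clearly to a single added carbon, even though the entering methyl brings no ring, no hydrogen-bond donor or acceptor and no net charge. Nothing at hand bears on the cause of this fall.

Going by these compounds, whether a longer chain or a methoxy group at this place would follow the ethyl remains open. Also open, on these data alone, is whether the same change on compound 1 would give a fall of similar size.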